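A few compounds are considered here, and "the series" means these few. Any claim that something is new, unique, unknown or untested is made for them only; others in the source may bear on it.

The three compounds measured so far:

Compound 1, `Cc1cccc(-n2nc(-c3ccccc3)c(C=O)c2/N=C/N(C)C)c1`, gives 8900 nM in a functional assay on NPC-TW01 cells (Homo sapiens) for inhibition, read by MTT assay, with a stated time of 72 h; a lower number here means a stronger inhibitor of growth, a higher number a weaker inhibitor of growth.
Compound 2, `Cc1ccc(-c2nn(-c3ccccc3)c(/N=C/N(C)C)c2C=O)cc1`, gives 9700 nM in this assay.
Compound 3, `CN(C)/C=N/c1c(C=O)c(-c2ccc(Cl)cc2)nn1-c1ccccc1`, gives 8100 nM in this assay.

Compound 3 has the lowest of the three numbers, but its gaps to compound 1 and to compound 2 are within the scatter, so the three compounds cannot be told apart on these numbers. Among the compounds with values here, the only step between two measured compounds that differ in one place is a 1.2-fold lower number from compound 2 to compound 3 (0.08 log units; within the scatter), a change of the substituent on the outer aromatic ring.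

Compound 4, `CN(C)/C=N/c1c(C=O)c(C(C)(C)C)nn1-c1ccccc1`, is the next compound to be measured. It differs from compound 3 in one place: tert-butyl in place of 4-chlorophenyl on an aromatic carbon. This change removes the whole aromatic ring rather than altering a substituent on it, so the step from compound 2 to compound 3 bears on it only loosely, and it showed no step beyond the scatter. Within the data shown here, no measured pair shows what replacing this ring does. The expectation for compound 4 is therefore a number near that of compound 3, with a wide range, amounting to a 1.4-fold higher number from compound 3 to compound 4 (0.13 log units; within the scatter). Compound 4 is estimated at 11000 nM, between 4000 nM and 30000 nM.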

Compound 4, concentration for 50% growth inhibition: > 50000 nM
Compound 4 was reported as a limit; the forecaster's own chance of this, stated with the estimate: 15%; at least 4.5-fold (0.65 log units) between middle value and limit.
By their numbers in this assay, from the lowest: compounds 3, 1 and 2 (each within the scatter of the next). At a limit, above all of these: compound 4.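

Swapping one substituent on the outer aromatic ring gave a 1.2-fold lower number from compound 2 to compound 3 (0.08 log units; within the scatter), which left open whether this position responds to change at all. Removing that ring does move the result: tert-butyl in place of 4-chlorophenyl on this aromatic carbon gives an at least 6.1-fold higher number from compound 3 to compound 4 (0.79 log units; beyond the scatter), and tert-butyl in place of 4-methylphenyl gives an at least 5.1-fold higher number from compound 2 to compound 4 (0.71 log units; beyond the scatter), so in these compounds growth inhibition in this assay is weakened by this change, while the substituent on the ring made no readable difference. The result for compound 4 is a limit and not a number: the limit of > 50000 nM in this assay, at which 1 of the 4 values shown sits.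

This change takes away an aromatic ring and also lowers the count of heavy atoms, so the compounds shown cannot say which of the two goes with the weaker result. A cyclohexyl group would keep a ring of carbon atoms without aromaticity, while a small aromatic ring such as thienyl or a pyridyl ring carrying a nitrogen would keep the aromaticity, and either could begin to separate the two.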